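Chloro in place of hydrogen on compound 3

This account rests on a few compounds, and the source may have more. Where it says the series, first, only, none or still open, it means among the compounds named here.

Compound 1 `Nc1cccc(-c2cn3nc(-c4cccs4)sc3n2)c1`: in a functional assay on FM3A cells (Mus musculus) for inhibition, read by cell counting, with a stated time of 2 days (a higher number here means a weaker inhibitor, a lower number a stronger inhibitor), compound 1 gives > 250000 nM, which is a limit of the assay and not a number.
Compound 2 `CCc1ccc(-c2nn3cc(-c4cccc(N)c4)nc3s2)cc1`: in this assay compound 2 gives 8200 nM.
Compound 3 `Nc1cccc(-c2cn3nc(-c4ccccc4)sc3n2)c1`: in this assay compound 3 gives 14000 nM.

Compound 3 holds the higher of the two numbers; its nearest neighbour is compound 2, with a 1.7-fold higher number from compound 2 to compound 3 (0.23 log units; within the scatter), a gap within the scatter. Compound 4 `Nc1cccc(-c2cn3nc(-c4ccc(Cl)cc4)sc3n2)c1` differs from compound 3 by chloro in place of hydrogen on an aromatic carbon. Going by the values given here, only one measured step also exchanges a substituent on that phenyl ring: a 1.7-fold higher number from compound 2 to compound 3 (0.23 log units; within the scatter). The other step, an at least 17-fold lower number from compound 1 to compound 3 (1.25 log units; beyond the scatter), alters a different ring and does not bear on this change. A step within the scatter is therefore expected in this assay, perhaps slightly lower. For compound 4 the estimate is 9000 nM, between 3000 nM and 30000 nM. The expected step is a 1.6-fold lower number from compound 3 to compound 4 (0.19 log units; within the scatter).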

Compound 4, half-maximal inhibitory concentration: 160000 nM
Beside the measured number, compound 4's estimate is 18-fold (1.25 log units) below it; measured number outside the range, above it.
By their numbers in this assay, from the lowest: compounds 2 and 3 (each within the scatter of the next); then compound 4. At a limit, above all of these: compound 1.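

In this assay, this position on the phenyl ring proves sensitive to what it carries: an 11-fold higher number from compound 3 to compound 4 (1.06 log units; beyond the scatter), whereas the swap of ethyl for hydrogen at the same place stayed within the scatter. Ethyl and chloro also part clearly here: a 20-fold higher number from compound 2 to compound 4 (1.29 log units; beyond the scatter), so the outcome depends on the group and not simply on the position being substituted. Compound 1 stands at a limit of the assay, not a number, so only a floor can be read: an at least 1.5-fold lower number from compound 1 to compound 4 (0.19 log units; that floor lies within the scatter).

From the compounds shown here alone, whether fluoro, bromo or methoxy at this position would follow chloro or ethyl stays open. So does whether chloro elsewhere on the ring would give a similar step.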